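Urea variants of a leucine-derived calpain-1 inhibitor

The source may report more compounds than this note shows. Statements on the series, on what has been measured and on what is new or still open speak of the compounds shown alone.

Measured compounds:
Compound 1, `CCNC(=O)CCCNC(=O)[C@H](CC(C)C)NC(=O)OC(C)(C)C`: 170 nM
Compound 2, `CCNC(=O)CCCNC(=O)[C@H](CC(C)C)NC(=O)N(C)C`: 333 nM

Compound 1 and compound 2 share a core in which a leucine-derived amide is capped on its amine nitrogen by a carbonyl group. In an assay on isolated protein (Sus scrofa) for inhibition of Calpain-1 catalytic subunit (Homo sapiens) (on this read-out lower numbers stand for stronger inhibition and higher numbers for weaker inhibition), compound 1 gives 170 nM. Compound 2 carries a dimethylamino group on that carbonyl carbon in place of the tert-butoxy group of compound 1, and the result is a 2.0-fold higher number from compound 1 to compound 2 (0.29 log units; within the scatter). Compound 2 therefore holds the highest of the two numbers recorded so far, though its gap to compound 1 lies within the scatter, so no order between them can be claimed.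

Compound 3, `CCNC(=O)CCCNC(=O)[C@H](CC(C)C)NC(=O)N1CCOCC1`, has not yet been tested. It differs from compound 2 in one place: morpholin-4-yl in place of dimethylamino on a carbonyl carbon. Going by the values given here, only the step from compound 1 to compound 2 bears on this change, and it stayed within the scatter. Among the compounds with values here, with one cap change of modest size as the sole guide, compound 3 is expected to land close to compound 2, with a 1.1-fold higher number from compound 2 to compound 3 (0.02 log units; within the scatter) as the anticipated step. The estimate for compound 3 in this assay is 350 nM, within a range of 150 nM to 800 nM.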

Compound 3, inhibition constant: 119 nM
Beside the measured number, compound 3's estimate is 2.9-fold (0.47 log units) above it; measured number outside the range, below it.
By their numbers in this assay, from the lowest: compounds 3, 1 and 2 (each within the scatter of the next, the first and the last beyond it).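

Going by these compounds alone, on the carbonyl carbon whose other neighbour is the amide-type nitrogen, the choice of cap can now be seen to matter in this assay: morpholin-4-yl in place of dimethylamino gives a 2.8-fold lower number from compound 2 to compound 3 (0.45 log units; beyond the scatter) and so provides the first step at this position that lies beyond the scatter. Morpholin-4-yl in place of tert-butoxy gives only a 1.4-fold lower number from compound 1 to compound 3 (0.15 log units; within the scatter) and stays within the scatter, so compound 1 and compound 3 cannot be ordered, and the two carbamoyl-type caps with a dimethylamino and a morpholin-4-yl group are separated only from each other. Nothing available bears on why the morpholin-4-yl cap gives the lower number.

What the compounds shown leave open is whether this step goes with the six-membered ring itself or with its oxygen, a question that a piperidin-1-yl cap or a diethylamino cap on the same carbonyl carbon would help to settle. Also open, from the compounds shown here alone, is whether the step holds on a changed core, for example with a benzyl group in place of the isobutyl side chain of the leucine part.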